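The compounds below may be only part of what the source reports. "The series", "measured", "known", "first", "only" and "open" are said of these compounds alone.

Notes on the series.

Compound 2 `O=C(Nc1cccc(-n2cc(-c3ccncc3)c(-c3cc(O)cc(Cl)c3)n2)c1)Nc1ccc(Cl)c(Cl)c1` is the point of departure. In a functional assay on CAKI-1 cells (Homo sapiens) for inhibition, read by sulforhodamine B assay, with a stated time of 48 h, tested at 1 uM (on this read-out higher numbers stand for a weaker effect at the one concentration tested and lower numbers for a stronger effect), compound 2 gives 54%, the second highest of the three numbers recorded, with compound 3 nearest and compound 1 furthest. Within the data shown here, compound 1 `O=C(Nc1cccc(-n2cc(-c3ccncc3)c(-c3cc(O)cc(Cl)c3)n2)c1)Nc1ccc(Cl)c(C(F)(F)F)c1` gives 98% in this assay, and the step of a number 44 percentage points lower from compound 1 to compound 2 (beyond the scatter) is the only measured step that changes a single place. Compound 3 `COc1cc(Cl)cc(-c2nn(-c3cccc(NC(=O)Nc4cc(C(F)(F)F)cc(C(F)(F)F)c4)c3)cc2-c2ccncc2)c1` gives 22% in this assay; it differs from compound 2 in more than one place, so only the two values are set side by side here.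

Compound 4 `COc1cc(Cl)cc(-c2nn(-c3cccc(NC(=O)Nc4ccc(Cl)c(Cl)c4)c3)cc2-c2ccncc2)c1` differs from compound 2 by methyl in place of hydrogen on an oxygen on an aromatic ring. Among the measured compounds shown here, no measured step changes hydrogen to methyl on that oxygen by itself, so the size of this step cannot be read from any single pair. Compound 3 carries the same methoxy group and, at 22%, stands well below compound 2, but it also carries a different urea aryl, so the comparison is indirect. The step of a number 44 percentage points lower from compound 1 to compound 2 (beyond the scatter) only shows that a single change elsewhere in the series has moved the number a long way.

On this footing a step of a number 14 percentage points lower from compound 2 to compound 4 (beyond the scatter) is expected, towards a lower number, with wide uncertainty. Compound 4 is expected at 40% in this assay, within 15% to 70%.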

Compound 4, a percentage reported as activity, at one concentration (the size of the read-out at that concentration, not a potency): 79%
Compound 4: the middle estimate sits 39 percentage points below what was measured; the measured number lies above the stated range.
By their numbers in this assay, from the lowest: compound 3; then compound 2; then compound 4; then compound 1.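

In this assay, among these compounds, the change from hydroxy to methoxy gives a number 25 percentage points higher from compound 2 to compound 4 (beyond the scatter), the first reading of this oxygen on its own, and it points towards a weaker effect at the one concentration tested. The methoxy group therefore does not by itself account for the low number of compound 3, 22%, which also carries a different urea aryl; this rests on a single pair. Nothing measured here bears on why adding the methyl on this oxygen moves the number.

Going by these compounds, whether this step keeps its direction and size with other urea aryl groups remains open. Also open, on these data alone, is how an ethyl ether or longer chain on this oxygen, or an amine in its place, would read against the hydroxy and methoxy compounds.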